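A few compounds are considered here, and "the series" means these few. Any claim that something is new, unique, unknown or untested is made for them only; others in the source may bear on it.

Compound 1 `Cn1nc(CN2CCCC2)nc1-c1ccc2ccsc2c1` gives in an assay on membranes from Jurkat cells for displacement of a labelled ligand from Sigma intracellular receptor 2 (Homo sapiens), read by scintillation counting, with a stated time of 1 h (on this read-out lower numbers stand for stronger inhibition and higher numbers for weaker inhibition), a reading of > 1000 nM, which is a limit of the assay and not a number. Compound 1 therefore stands at the limit of > 1000 nM in this assay, at which 1 of the 2 values shown sits, with no measured value of its own. Compound 2 `CC(C)n1nc(CN2CCCC2)nc1-c1ccc(C(C)(C)C)cc1`, a differently built member of the series, gives 1460 nM in this assay. Compound 3 `Cn1nc(CN2CCCC2)nc1-c1ccc2cc(Cl)sc2c1` differs from compound 1 by chloro in place of hydrogen on an aromatic carbon. Among the measured compounds shown here, no measured step bears on this change, so no step beyond the usual scatter is expected for a step that the limit leaves unreadable from compound 1 to compound 3. Compound 3 is estimated at 1500 nM, with a range from 500 nM to 5000 nM.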

Compound 3, inhibition constant: 1000 nM
For compound 3 the middle estimate is 1.5-fold (0.18 log units) above the measured one, and the stated range covers the measured number.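

In this assay compound 3 gives 1000 nM, so chloro on this aromatic carbon next to the ring sulfur yields a measured number on the core of compound 1. Compound 1 gives > 1000 nM, which is a limit of the assay and not a number. Chloro in place of hydrogen gives a number no higher from compound 1 to compound 3 (the limit leaves the size open). The size of the step from hydrogen to chloro therefore cannot be read: the limit of > 1000 nM in this assay, at which 1 of the 3 values shown sits.

On these data alone, whether an amine, a carboxylic acid or a methoxy group on this same carbon would give a different reading stays open. So does the reading with bromo or fluoro there.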